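This account rests on a few compounds, and the source may have more. Where it says the series, first, only, none or still open, it means among the compounds named here.

In a functional assay on MCF7 cells (Homo sapiens) for inhibition, read by sulforhodamine B assay (a lower number here means a stronger inhibitor, a higher number a weaker inhibitor), the compounds read as follows:
- compound 1 `O=C1C=C(NCc2ccccc2)C(=O)c2c1nc1n2[C@H]2OC[C@@H](O)[C@H]2OC1` gives > 8000 nM as a limit, not a number
- compound 2 `CCc1ccc(NC2=CC(=O)c3c(nc4n3[C@H]3OC[C@@H](O)[C@H]3OC4)C2=O)cc1` gives 8990 nM as a number
- compound 3 `CCc1ccc(NC2=CC(=O)c3nc4n(c3C2=O)[C@H]2OC[C@@H](O)[C@H]2OC4)cc1` gives 960 nM as a number

Compound 2 stands at 8990 nM and compound 3 stands at 960 nM in this comparison, so the number of compound 2 is the higher of the two. Compound 1 gave only a limit of > 8000 nM and cannot be placed exactly.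

Compound 4 `COc1ccc(NC2=CC(=O)c3c(nc4n3[C@H]3OC[C@@H](O)[C@H]3OC4)C2=O)cc1` keeps the whole of compound 2 except one group. The change is methoxy in place of ethyl on an aromatic carbon with methoxy in place of ethyl on an aromatic carbon, para to a large group.

For the measured compounds named here, only one measured step exists, an at least 8.3-fold lower number from compound 1 to compound 3 (0.92 log units; beyond the scatter) and it is beyond the scatter. It swaps benzyl for 4-ethylphenyl on an amine nitrogen, though, and leaves the question of ethyl against methoxy untouched. Compound 2 and compound 3 both carry 4-ethylphenyl on a differently arranged core, so that step cannot simply be carried over.

Going by the values given here, with compound 2 at 8990 nM and no measured step testing this swap, no step beyond the scatter is expected, and the estimated change is a 1.3-fold lower number from compound 2 to compound 4 (0.11 log units; within the scatter) overall. Compound 4 might also return only a limit, as compound 1 did. For compound 4 the expected value is 7000 nM with an estimated range from 2500 nM to 20000 nM in all.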

Compound 4, half-maximal inhibitory concentration: 4470 nM
Estimate against measurement, compound 4: 1.6-fold (0.19 log units) above; the measured number falls inside the stated range.
By their numbers in this assay, from the lowest: compound 3; then compounds 4 and 2 (each within the scatter of the next).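

In this assay, putting methoxy in place of ethyl on the aromatic carbon para to a large group gives a 2.0-fold lower number from compound 2 to compound 4 (0.30 log units; within the scatter). For the compounds shown here, this is the first direct reading at this position, since the earlier step changed benzyl to 4-ethylphenyl on the amine nitrogen and left the ethyl-to-methoxy question untouched; here, a swap that brings in an oxygen and one hydrogen-bond acceptor, with the heavy-atom count unchanged, does not move the number beyond the usual scatter. Compound 1 gave a limit, not a number, and so it offers no exact reference point for this pair: the limit of > 8000 nM in this assay, at which 1 of the 4 values shown sits.

Going by these compounds alone, the single pair rests on only two groups at this position, so it remains unknown how an amine, a carboxylic acid, a chlorine atom or a longer chain such as butyl would read there. On these data alone, it is also open whether methoxy in place of ethyl would behave the same way on the differently arranged core of compound 3, which carries the same 4-ethylphenyl group.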